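Methyl in Place of Trifluoromethyl on the Pendant Phenyl

The compounds below may be only part of what the source reports. "The series", "measured", "known", "first", "only" and "open" are said of these compounds alone.

For the measured compounds named here, compound 2 `Cc1cc(-c2ccc(C(F)(F)F)cc2)cc(C)c1Nc1ccnc(Nc2ccc(C#N)cc2)n1` gives 4160 nM in an ADME assay on MT4 cells (Homo sapiens) for cytotoxicity, read by MTT assay, with a stated time of 4 days (on this read-out lower numbers stand for higher toxicity in this test and higher numbers for lower toxicity in this test), the highest of the two numbers so far, with compound 1 `COc1ccc(-c2cc(C)c(Nc3ccnc(Nc4ccc(C#N)cc4)n3)c(C)c2)cc1` nearest at 2890 nM. Compound 3 `Cc1ccc(-c2cc(C)c(Nc3ccnc(Nc4ccc(C#N)cc4)n3)c(C)c2)cc1` differs from compound 2 by methyl in place of trifluoromethyl on an aromatic carbon. Going by the values given here, the one step bearing on this position, a 1.4-fold higher number from compound 1 to compound 2 (0.16 log units; within the scatter), lay within the scatter, so any change here is expected to be small. Compound 3 is therefore estimated at 3500 nM, with a range from 1500 nM to 8500 nM. That estimate means an expected step of a 1.2-fold lower number from compound 2 to compound 3 (0.08 log units; within the scatter), not beyond the scatter in either direction.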

Compound 3, half-maximal cytotoxic concentration: 5570 nM
Compound 3: middle estimate off by 1.6-fold (0.20 log units), on the low side; the measured number falls inside the stated range.
By their numbers in this assay, from the lowest: compounds 1, 2 and 3 (each within the scatter of the next).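

In this assay, methyl joins trifluoromethyl and methoxy at this position without any step beyond the scatter, with a 1.3-fold higher number from compound 2 to compound 3 (0.13 log units; within the scatter) and with a 1.9-fold higher number from compound 1 to compound 3 (0.28 log units; within the scatter) as well. Across compounds 1, 2 and 3, then, this position tolerates replacing one group with another without a change that can be told apart from the scatter, whether the group carries fluorine, oxygen or carbon and hydrogen alone. Nothing measured here bears on why these numbers lie so close together. On these data alone, whether an amine, a carboxylic acid or a longer chain in this place would also stay within the scatter remains open.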